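Basic side chain in place of the urea aryl group

The compounds below may be only part of what the source reports. "The series", "measured", "known", "first", "only" and "open" are said of these compounds alone.

compound 1, `CCN(CC)Cc1ccc(NC(=O)Nc2ccc3ncnc(Nc4cccc(C(F)(F)F)c4)c3c2)cc1`: in a functional assay on A549 cells (Homo sapiens) for antiproliferative activity, read by MTT assay, with a stated time of 72 h (on this read-out higher numbers stand for weaker inhibition and lower numbers for stronger inhibition), compound 1 gives 2070 nM
compound 2, `O=C(Nc1ccccc1)Nc1ccc2ncnc(Nc3cccc(C(F)(F)F)c3)c2c1`: compound 2 gives > 10000 nM, a limit of the assay and not a number
compound 3, `Cc1ccc(NC(=O)Nc2ccc3ncnc(Nc4cccc(C(F)(F)F)c4)c3c2)cc1`: compound 3 gives 4140 nM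
compound 4, `CN1CCN(CCNC(=O)Nc2ccc3ncnc(Nc4cccc(C(F)(F)F)c4)c3c2)CC1`: not yet measured

Compound 3 stands at the higher of the two numbers that are known; its nearest neighbour is compound 1, and the step of a 2.0-fold higher number from compound 1 to compound 3 (0.30 log units; within the scatter) leaves the two unseparated. Compound 2 sits at the limit of > 10000 nM in this assay, at which 1 of the 3 values shown sits. From there the step of an at least 2.4-fold lower number from compound 2 to compound 3 (0.38 log units; beyond the scatter) is a real gain, and the step of an at least 4.8-fold higher number from compound 1 to compound 2 (0.68 log units; beyond the scatter) shows that losing the (diethylamino)methyl group costs more than losing only the diethylamino part.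

The change to compound 4 is 2-(4-methylpiperazin-1-yl)ethyl in place of 4-methylphenyl on an amide-type nitrogen. For the measured compounds named here, no measured step exchanges the whole aryl group for a chain, so the only guide is that compound 1, the one measured compound with a basic amine on the urea side, gives the lowest number, while compound 2 without any such group is the weakest. Compound 4 is therefore expected to land near compound 1, a modest step of a 1.7-fold lower number from compound 3 to compound 4 (0.22 log units; within the scatter), with compound 4 estimated at 2500 nM, between 800 nM and 8000 nM.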

Compound 4, half-maximal inhibitory concentration: > 10000 nM
Compound 4: a limit, no number (the forecaster's own chance of this, stated with the estimate: 15%); middle value at least 4.0-fold (0.60 log units) from the limit.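

Exchanging the aryl group on the amide-type nitrogen for 2-(4-methylpiperazin-1-yl)ethyl does not reproduce what the (diethylamino)methyl group gives in this assay: there is an at least 2.4-fold higher number from compound 3 to compound 4 (0.38 log units; beyond the scatter), and an at least 4.8-fold higher number from compound 1 to compound 4 (0.68 log units; beyond the scatter). An amine in the side chain is therefore not enough on its own at this position, since compound 1 and compound 4 both carry one and are separated, and the plain phenyl of compound 2 shows that an aromatic ring alone is not enough either. Compound 4 gives a limit and not a number, the step to compound 2 cannot be read, and the two compounds sit at the same limit: the limit of > 10000 nM in this assay, at which 2 of the 4 values shown sit.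

The compounds shown do not separate the loss of the aromatic ring from the change of amine. A 2-(diethylamino)ethyl chain, or a 4-((4-methylpiperazin-1-yl)methyl)phenyl group, on the amide-type nitrogen would pull these two changes apart.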